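This account rests on a few compounds, and the source may have more. Where it says the series, first, only, none or still open, it means among the compounds named here.

Compound 1 `N#Cc1cnn(C(=O)NCc2ccc(OCc3ccccc3)cc2)c1` and compound 2 `O=C(NCc1ccc(OC(c2ccccc2)c2ccccc2)cc1)n1cccn1` were both examined in an assay on membranes from brain for binding affinity to neutral cholesterol ester hydrolase 1 (Mus musculus), read by fluorescence, with stated times of 1 h and 30 min; on this read-out higher numbers stand for weaker inhibition and lower numbers for stronger inhibition. For compound 1 the assay reached only its limit, > 100000 nM. For compound 2 the assay likewise reported only a limit, > 100000 nM. Compound 2 therefore stands at the limit of > 100000 nM in this assay, at which 2 of the 2 values shown sit. Compound 3 `N#Cc1cnn(C(=O)NCc2ccc(OC(c3ccccc3)c3ccccc3)cc2)c1` differs from compound 2 by cyano in place of hydrogen on an aromatic carbon. Among the compounds with values here, no measured step between compounds is available here, so no shift beyond the usual scatter is expected from this change. Compound 3 is therefore expected to give about 100000 nM, within 30000 nM to 300000 nM, and the step this estimate implies from compound 2 to compound 3 is a number no higher from compound 2 to compound 3 (the limit leaves the size open).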

Compound 3, half-maximal inhibitory concentration: > 100000 nM
Compound 3 ended at the assay's limit (the forecaster's own chance of this, stated with the estimate: 80%); the middle value lies on the limit itself.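

Within the data shown here, compound 3 joins compound 1 and compound 2 at the limit of this assay, so no step among them can be read. The compounds shown leave open whether the cyano or phenyl change affects inhibition at all.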